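Mirror image of a benzyl amide awaits its cytotoxicity reading

The source may report more compounds than this note shows. Statements on the series, on what has been measured and on what is new or still open speak of the compounds shown alone.

compound 1 `COc1cc([C@@H]2C[C@]2(CO)C(=O)Nc2ccccc2Cl)cc(OC)c1OC`: 4400 nM
compound 2 `COc1cc([C@@H]2C[C@]2(CO)C(=O)NCc2ccc(C)cc2)cc(OC)c1OC`: 10500 nM

In a functional assay on A549 cells (Homo sapiens) for cytotoxicity, read by MTT assay, with a stated time of 48 h (on this read-out higher numbers stand for weaker inhibition and lower numbers for stronger inhibition), compound 2, at 10500 nM, holds the higher of the two numbers and is therefore the weaker inhibitor of the pair. The next compound to be tested, compound 3 `COc1cc([C@H]2C[C@@]2(CO)C(=O)NCc2ccc(C)cc2)cc(OC)c1OC`, has the same atoms and bonds as compound 2: the two compounds have the same atoms and bonds and differ only in configuration as drawn: 2 of 2 stereo elements differ (all stereocentres are inverted: mirror images); a stereocentre at a saturated ring carbon is drawn S in compound 2 and R in compound 3; a stereocentre at a saturated ring carbon is drawn S in compound 2 and R in compound 3.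

Going by the values given here, only one measured step is available, and it bears on this change only indirectly. That step, a 2.4-fold higher number from compound 1 to compound 2 (0.38 log units; beyond the scatter), places 4-methylbenzyl in place of 2-chlorophenyl on an amide-type nitrogen and leaves the drawn configuration untouched. Among the compounds with values here, it shows a modest response to a change of amide substituent, but no mirror-image pair has been measured, so the data give no direction for inverting both stereocentres. No step beyond the scatter is therefore expected in this assay, although a real difference in either direction remains possible, and the range is kept wide. The estimate amounts to an expected 1.1-fold lower number from compound 2 to compound 3 (0.02 log units; within the scatter). Compound 3 is expected at 10000 nM, with an estimated range of 4000 nM to 30000 nM.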

Compound 3, half-maximal inhibitory concentration: 63800 nM
Estimate against measurement, compound 3: 6.4-fold (0.80 log units) below; measured number above the stated range.
By their numbers in this assay, from the lowest: compound 1; then compound 2; then compound 3.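

In this assay, going by these compounds alone, the mirror-image change gives a 6.1-fold higher number from compound 2 to compound 3 (0.78 log units; beyond the scatter), so the drawn configuration of the shared core is itself a determinant of the reading, something the earlier compounds could not show, as both are drawn with the same configuration. The gap can be assigned to configuration alone because nothing else separates the two structures: the fact that compounds 2 and 3 differ only in the configuration as drawn This change of configuration also moves the number further than the only earlier step, a 2.4-fold higher number from compound 1 to compound 2 (0.38 log units; beyond the scatter), so, among the compounds shown, the arrangement in space counts for more than the swap of amide substituent, with the configuration drawn in compound 2 giving the stronger inhibition of the mirror-image pair.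

Both stereocentres invert together, so the compounds shown do not tell whether one of them carries the difference or both contribute. As far as these compounds go, it also remains open whether the same preference would hold with the 2-chlorophenyl group of compound 1, or with a longer alkyl chain or a pyridylmethyl group in place of 4-methylbenzyl on the amide-type nitrogen.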